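Replacing 2-aminophenyl with hydroxy on an amide-type nitrogen

This account rests on a few compounds, and the source may have more. Where it says the series, first, only, none or still open, it means among the compounds named here.

In a functional assay on MDA-MB-231 cells (Homo sapiens) for inhibition, read by MTT assay, with a stated time of 48 h (a higher number here means a weaker inhibitor, a lower number a stronger inhibitor), compound 1 (`COc1cc(/C=C/C(=O)NO)ccc1OCC(=O)Nc1ccccc1F`) gives 8300 nM as its half-maximal inhibitory concentration. Compound 2 (`COc1cc(/C=C/C(=O)Nc2ccccc2N)ccc1OCC(=O)Nc1cccc(F)c1`) reads > 100000 nM in this assay and this is a limit of the assay, not a number.

Compound 3 (`COc1cc(/C=C/C(=O)NO)ccc1OCC(=O)Nc1cccc(F)c1`) departs from compound 2 in one place. The change is hydroxy in place of 2-aminophenyl on an amide-type nitrogen and it puts hydroxy in place of 2-aminophenyl on an amide-type nitrogen.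

For the measured compounds named here, no measured step between two compounds is available to size this change, so the only guide is a single neighbouring value. Compound 1 also carries hydroxy on an amide-type nitrogen and stands at 8300 nM in this assay and the expectation for compound 3 rests on that figure. The expected step of an at least 14-fold lower number from compound 2 to compound 3 (1.15 log units; beyond the scatter) is large, points toward a stronger inhibitor and should lie well beyond the usual scatter of this assay readings. For compound 3 the estimated value is 7000 nM with an expected range from 2500 nM to 20000 nM in this assay readings.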

Compound 3, half-maximal inhibitory concentration: 1450 nM
The estimate for compound 3 lay 4.8-fold (0.68 log units) above the measured number, outside the stated range (below it).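

Hydroxy in place of 2-aminophenyl on an amide-type nitrogen gives an at least 68-fold lower number from compound 2 to compound 3 (1.83 log units; beyond the scatter) in this assay, the first measured size for this change. That size is only a lower bound, since compound 2 stands at a limit of the assay and not at a number: the limit of > 100000 nM in this assay, at which 1 of the 3 values shown sits. The group on the other amide-type nitrogen also matters once hydroxy is in place: 3-fluorophenyl in place of 2-fluorophenyl gives a 5.7-fold lower number from compound 1 to compound 3 (0.76 log units; beyond the scatter), so the reading of this series does not depend on the hydroxy alone.

The compounds shown leave open whether another small group on that nitrogen, such as methoxy or a plain amino group, would keep the reading of compound 3, and whether a 2-aminophenyl compound would respond to the fluorine shift at all, as compound 2 offers no number to compare. They also leave open whether the fluorine itself counts, since a plain phenyl or a 3-chlorophenyl on the other amide-type nitrogen would be needed to separate the atom from its place on the ring.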